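Carbamate in place of amide on the shared core

The source may hold more compounds than are shown below. What is called first, only, known or untested is meant among the compounds shown, and "the series" means these compounds.

Compound 1 `O=C(CC1CCCCCC1)N1CCC(c2nc(-c3ccc4ccccc4n3)no2)CC1` carries a cycloheptylmethyl group on the carbonyl of its piperidine amide. In a functional assay on Shh Light II cells (Mus musculus) for inhibition, read by a luciferase reporter (a lower number here means a stronger inhibitor, a higher number a weaker inhibitor), compound 1 gives 840 nM, the second highest of the three numbers measured on this core. Compound 2 `O=C(NCC1CCC1)N1CCC(c2nc(-c3ccc4ccccc4n3)no2)CC1` gives 410 nM in this assay, and compound 3 `O=C(NC1CC[S+]([O-])CC1)N1CCC(c2nc(-c3ccc4ccccc4n3)no2)CC1` gives 850 nM.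

Two of the measured steps start from compound 1. Exchanging the cycloheptylmethyl for a (cyclobutylmethyl)amino group brought a 2.0-fold lower number from compound 1 to compound 2 (0.31 log units; beyond the scatter), a modest gain; exchanging it for the sulfoxide-bearing ring brought a 1.0-fold higher number from compound 1 to compound 3 (0.01 log units; within the scatter), no change at all. Between compounds 2 and 3 the step was a 2.1-fold higher number from compound 2 to compound 3 (0.32 log units; beyond the scatter).

Compound 4 `COc1ccccc1OC(=O)N1CCC(c2nc(-c3ccc4ccccc4n3)no2)CC1` differs from compound 1 by 2-methoxyphenoxy in place of cycloheptylmethyl on a carbonyl carbon. Neither measured step replaces the carbon ring with an aromatic ring bound through oxygen, so the two steps from compound 1 only show that this position tolerates substitution within a narrow band. Compound 4 is therefore expected to stay close to compound 1, with a 1.2-fold lower number from compound 1 to compound 4 (0.08 log units; within the scatter) expected to fall within or just beyond the scatter. The estimate for compound 4 in this assay is 700 nM, with a range from 250 nM to 2500 nM.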

Compound 4, half-maximal inhibitory concentration: 250 nM
The estimate for compound 4 lay 2.8-fold (0.45 log units) above the measured number, and the stated range covers the measured number.
By their numbers in this assay, from the lowest: compounds 4 and 2 (each within the scatter of the next); then compounds 1 and 3 (each within the scatter of the next).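

In this assay, among these compounds, the 2-methoxyphenoxy group on the carbonyl carbon gave a 3.4-fold lower number from compound 1 to compound 4 (0.53 log units; beyond the scatter) and also a 3.4-fold lower number from compound 3 to compound 4 (0.53 log units; beyond the scatter), so this position accepts an aromatic ring bound through oxygen and the number moves beyond the narrow band that the earlier steps from compound 1 had suggested. The step of a 1.6-fold lower number from compound 2 to compound 4 (0.21 log units; within the scatter) leaves compound 4 and compound 2 together as the better pair, although their groups differ in ring type and in the atom bound to the carbonyl carbon. Neither the aromatic ring nor the oxygen link is therefore required for this level of inhibition, and compound 3 shows that a nitrogen link alone does not secure it, since compound 3 stays with compound 1 despite having that link.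

No evidence is available to explain these differences. The compounds shown leave open whether the methoxy group contributes anything to compound 4, which a plain phenoxy group on the same carbonyl carbon would address. A phenylamino group there would likewise separate the effect of the aromatic ring from that of the oxygen link.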